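From compound 3 to compound 4: a pyridin-3-yl swap

The compounds below may be only part of what the source reports. "The series", "measured", "known", "first", "only" and "open" are said of these compounds alone.

Measured in an ADME assay (liver) for metabolic stability, with Liver microsome (Homo sapiens) as the target, using microsomes and NADPH, with a stated time of 30 min, tested at 1 uM; on this read-out lower numbers stand for slow clearance and higher numbers for fast clearance:
compound 1 `COc1cc(C(O)(C(F)(F)F)C(F)(F)F)cnc1N1CCN(S(=O)(=O)c2ccc(N)nc2)CC1`: < 14 mL.min-1.g-1 (a limit)
compound 2 `Nc1ccc(S(=O)(=O)N2CCN(c3ncc(C(O)(C(F)(F)F)C(F)(F)F)cc3C#CCCO)CC2)cn1`: < 14 mL.min-1.g-1 (a limit)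
compound 3 `Nc1ccc(S(=O)(=O)N2CCN(c3ncc(C(O)(C(F)(F)F)C(F)(F)F)cc3-c3cccc(F)c3)CC2)cn1`: 25 mL.min-1.g-1

For the measured compounds named here, compound 3 stands at 25 mL.min-1.g-1 as the only true number in this small set. The other two compounds give only the limit of < 14 mL.min-1.g-1 in this assay, at which 2 of the 3 values shown sit, and no number.

Compound 4 `Nc1ccc(S(=O)(=O)N2CCN(c3ncc(C(O)(C(F)(F)F)C(F)(F)F)cc3-c3cccnc3)CC2)cn1` carries pyridin-3-yl in place of 3-fluorophenyl on an aromatic carbon.

Two measured steps reach the same position, an at least 1.7-fold higher number from compound 1 to compound 3 (0.25 log units; that floor lies within the scatter) and an at least 1.7-fold higher number from compound 2 to compound 3 (0.25 log units; that floor lies within the scatter), and both are only floors. Neither exchanges one aromatic ring for another, so neither measures this change directly. They give no firm size, and the expectation therefore starts from compound 3 at 25 mL.min-1.g-1 and allows a modest fall towards the values of the other two compounds. The expected change is a 1.6-fold lower number from compound 3 to compound 4 (0.19 log units; within the scatter), and this small downward step is an estimate. The assay may well report only a limit here. For compound 4 the estimated value is 16 mL.min-1.g-1, with an expected range of 10 mL.min-1.g-1 to 30 mL.min-1.g-1.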

Compound 4, intrinsic clearance in microsomes: 17 mL.min-1.g-1
Compound 4: middle estimate off by 1.1-fold (0.03 log units), on the low side; the measured number falls inside the stated range.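

In this assay, the step that exchanges one aromatic ring for another at this position is a 1.5-fold lower number from compound 3 to compound 4 (0.17 log units; within the scatter), so on this read-out pyridin-3-yl and 3-fluorophenyl cannot be told apart. The steps from the two other substituents remain floors: an at least 1.2-fold higher number from compound 1 to compound 4 (0.08 log units; that floor lies within the scatter) with methoxy leaving, and an at least 1.2-fold higher number from compound 2 to compound 4 (0.08 log units; that floor lies within the scatter) with 4-hydroxybut-1-yn-1-yl leaving. Both start from a value that is a limit and not a number: the limit of < 14 mL.min-1.g-1 in this assay, at which 2 of the 4 values shown sit.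

On these data alone, it remains open whether pyridin-4-yl, a morpholine or a carboxylic acid at this position would move intrinsic clearance beyond the scatter. The true size of the steps from methoxy and from 4-hydroxybut-1-yn-1-yl also remains open, and the compounds shown cannot give it.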